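From pentyloxy to 8-acetamidooctyl on the shared core

The source may report more compounds than this note shows. Statements on the series, on what has been measured and on what is new or still open speak of the compounds shown alone.

Values in a functional assay on Hs-578T cells (Homo sapiens) for antiproliferative activity; a higher number here means a weaker inhibitor of growth, a lower number a stronger inhibitor of growth:
- compound 1 `COCCCCCCCCCCCCCCC/C=C1/CC(CO)(COC(=O)C(C)(C)C)OC1=O`: 6.77 ug/mL
- compound 2 `CCCCCOCCCCCCC/C=C1\CC(CO)(COC(=O)C(C)(C)C)OC1=O`: 3 ug/mL
- compound 3 `CC(C)(C)C(=O)OCC1(CO)C/C(=C/CCCCCCCCCCCCCCC=O)C(=O)O1`: > 10 ug/mL (a limit, not a number)

Of the two exact values, compound 2 has the lower, at 3 ug/mL, and compound 1 stands higher at 6.77 ug/mL, a gap beyond the usual scatter. The next structure, compound 4 `CC(=O)NCCCCCCCCCCCCCCC/C=C1\CC(CO)(COC(=O)C(C)(C)C)OC1=O`, differs from compound 2 by 8-acetamidooctyl in place of pentyloxy on a saturated chain carbon, seven bonds along the chain from a double-bonded chain carbon. Among the compounds with values here, no measured step makes this same change. The nearest is an at least 1.4-fold higher number from compound 1 to compound 3 (0.16 log units; that floor lies within the scatter), with formyl in place of methoxymethyl on a saturated chain carbon, ten or more bonds along the chain from a double-bonded chain carbon. That step points toward a higher number in this assay, but only weakly, and it concerns different groups. A modest move in that direction is therefore expected, with wide uncertainty. The expected change is a 2.2-fold higher number from compound 2 to compound 4 (0.34 log units; beyond the scatter). For compound 4 the estimate is 6.5 ug/mL, with an expected range from 2.5 ug/mL to 15 ug/mL.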

Compound 4, concentration for 50% growth inhibition: > 10 ug/mL
Compound 4 ended at the assay's limit; the forecaster's own chance of this, stated with the estimate: 25%; at least 1.5-fold (0.18 log units) between middle value and limit.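

In this assay compound 4 gives > 10 ug/mL, which is a limit and not a number. Even so, the single change on the chain gives an at least 3.3-fold higher number from compound 2 to compound 4 (0.52 log units; beyond the scatter), a step beyond the scatter, whereas the only earlier step, an at least 1.4-fold higher number from compound 1 to compound 3 (0.16 log units; that floor lies within the scatter), involved other groups and could not be told from scatter. Only the floor of the new step can be read, and its full size stays unknown: the limit of > 10 ug/mL in this assay, at which 2 of the 4 values shown sit.

The compounds shown leave open whether the weaker growth inhibition follows the acetamido group or the greater length of the chain, as 8-acetamidooctyl brings both. A plain octyl chain, or a chain ending in an amine or a carboxylic acid, at the same place would help to separate the two.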